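The source may hold more compounds than are shown below. What is called first, only, known or untested is meant among the compounds shown, and "the series" means these compounds.

Measured compounds in the series:

- Compound 1, `CCc1ccc2nc(C(=O)Nc3c(F)cc(-c4cccc(F)c4)cc3F)c(C)c(C(=O)O)c2c1`, in a functional assay on A-375 cells (Homo sapiens) for antiproliferative activity, read by MTT assay, with a stated time of 24 h, tested at 1.23 ug/mL (on this read-out higher numbers stand for a stronger effect at the one concentration tested and lower numbers for a weaker effect), gives 17.7%.
- Compound 2, `Cc1c(C(=O)Nc2c(F)cc(-c3cccc(F)c3)cc2F)nc2ccc(F)cc2c1C(=O)O`, in this assay gives 16.3%.
- Compound 3, `CCOc1ccc2nc(C(=O)Nc3c(F)cc(-c4cccc(F)c4)cc3F)c(C)c(C(=O)O)c2c1`, in this assay gives 26.7%.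

Compound 3 carries the highest of the three numbers, but its lead is uneven: the step of a number 9 percentage points higher from compound 1 to compound 3 (within the scatter) lies within the scatter, whereas the step of a number 10.4 percentage points higher from compound 2 to compound 3 (beyond the scatter) lies beyond it, if modestly. The step of a number 1.4 percentage points lower from compound 1 to compound 2 (within the scatter) adds nothing in either direction.

Compound 4, `COc1ccc2nc(C(=O)Nc3c(F)cc(-c4cccc(F)c4)cc3F)c(C)c(C(=O)O)c2c1`, has not been measured. It differs from compound 3 by hydrogen in place of methyl on a saturated chain carbon bound to an oxygen on an aromatic ring. Among the measured compounds shown here, no measured step shortens the chain on this oxygen; the two steps that involve the ethoxy group, from compound 1 and from compound 2 to compound 3, concern its arrival, not its length. The change is one carbon on the chain. The expectation for this assay is therefore a step of no more than the scatter, with a slight lean toward a lower number, estimated as a number 4.7 percentage points lower from compound 3 to compound 4 (within the scatter). For compound 4 the expected value is 22%, within a range of 11% to 33%.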

Compound 4, a percentage reported as inhibition, at one concentration (the size of the read-out at that concentration, not a potency): 10.2%
Estimate against measurement, compound 4: 11.8 percentage points above; the whole stated range lies above it.
By their numbers in this assay, from the lowest: compounds 4, 2, 1 and 3 (each within the scatter of the next, the first and the last beyond it).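

In this assay, among the compounds shown here, cutting ethoxy back to methoxy gives a number 16.5 percentage points lower from compound 3 to compound 4 (beyond the scatter), so a change of one methyl on this oxygen can be read here, which the earlier compounds, with only ethoxy at this place, could not show. Methoxy does not share the edge of ethoxy over fluoro: a number 6.1 percentage points lower from compound 2 to compound 4 (within the scatter) and a number 7.5 percentage points lower from compound 1 to compound 4 (within the scatter) both stay within the scatter, leaving methoxy not separable from fluoro or ethyl on this aromatic carbon, while ethoxy separates from methoxy and fluoro but not from ethyl. No available evidence bears on this step.

On these data alone, whether a longer chain on this oxygen, such as propoxy, or a branched one such as isopropoxy, would hold the ethoxy value remains open. So does the behaviour of an amine or a hydroxyl on the same aromatic carbon, and all of these readings rest on one concentration, not on a potency.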